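Carboxy added to the methoxy carbon of compound 1

The source may report more compounds than this note shows. Statements on the series, on what has been measured and on what is new or still open speak of the compounds shown alone.

In an ADME assay on Raji cells (Homo sapiens) for cytotoxicity, with a stated time of 72 h (a higher number here means that more compound is needed for the effect, a lower number that less compound is needed), compound 1 `COc1cc(Cl)c(C(=O)Nc2cccc(-c3nc4ccccc4s3)c2)cc1[N+](=O)[O-]` gives only a limit, > 25000 nM (the limit of > 25000 nM in this assay, at which 1 of the 3 values shown sits). Compound 2 `O=C(Nc1nc(-c2ccc(F)c(F)c2)cs1)c1cc([N+](=O)[O-])ccc1Cl` gives 13000 nM in this assay. Compound 3 `O=C(Nc1nc2ccc(Cl)cc2s1)c1cc([N+](=O)[O-])ccc1Cl` likewise reaches only a limit, > 27000 nM (the limit of > 27000 nM in this assay, at which 1 of the 3 values shown sits). Among the measured compounds shown here, none of the three measured compounds therefore shows cytotoxicity well inside the range of this assay, and no step between two measured compounds that differ in one place is available to lean on. Compound 4 `O=C(O)COc1cc(Cl)c(C(=O)Nc2cccc(-c3nc4ccccc4s3)c2)cc1[N+](=O)[O-]` differs from compound 1 by carboxy in place of hydrogen on a saturated chain carbon bound to an oxygen on an aromatic ring. Without a measured step to guide it, no shift beyond the usual scatter is expected from this change. Compound 4 is thus expected to give 30000 nM in this assay, most likely between 10000 nM and 90000 nM. The expected step that the limit leaves unreadable from compound 1 to compound 4 is therefore close to none.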

Compound 4, half-maximal effective concentration: > 25000 nM
Compound 4: only a limit was reported (the forecaster's own chance of this, stated with the estimate: 80%); the middle value does not contradict the limit.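

Compound 1 and compound 4 both reach only a limit, so the step between them cannot be read: the limit of > 25000 nM in this assay, at which 2 of the 4 values shown sit.

The compounds shown leave open whether carboxy in place of hydrogen at this place shifts the concentration needed in this assay at all.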